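The compounds below may be only part of what the source reports. "The series", "measured", "known", "first", "only" and "open" are said of these compounds alone.

In a functional assay on BHK cells for positive allosteric modulation of metabotropic glutamate receptor 5 (Homo sapiens), read by FLIPR and calcium flux (on this read-out higher numbers stand for an effect only at larger amounts of compound and lower numbers for an effect already at smaller amounts), compound 3 `CN1CCN(C(=O)c2ccc(C#Cc3ccccc3)nc2)CC1` gives 1600 nM and stands highest of the three measured compounds; compound 2 `O=C(c1ccc(C#Cc2ccccc2)nc1)N1CCCCC1` gives 280 nM and compound 1 `O=C(NCc1ccsc1)c1ccc(C#Cc2ccccc2)nc1` gives 140 nM. Compound 4 `O=C(c1ccc(C#Cc2ccccc2)nc1)N1CCOCC1` differs from compound 3 by morpholin-4-yl in place of 4-methylpiperazin-1-yl on a carbonyl carbon. The step that bears most on this change is a 5.7-fold higher number from compound 2 to compound 3 (0.76 log units; beyond the scatter), where one six-membered ring with two hetero atoms entered on the same carbonyl carbon; the step of an 11-fold higher number from compound 1 to compound 3 (1.06 log units; beyond the scatter) also ended at compound 3. Since compound 4 again carries a six-membered ring with two hetero atoms, the expected step of a 2.5-fold lower number from compound 3 to compound 4 (0.39 log units; beyond the scatter) is a modest fall in this assay, not a full return to compound 2. Compound 4 is therefore estimated at 650 nM, within a range of 250 nM to 1700 nM.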

Compound 4, half-maximal effective concentration: 990 nM
Compound 4: middle estimate off by 1.5-fold (0.18 log units), on the low side; the measured number falls inside the stated range.
By their numbers in this assay, from the lowest: compounds 1 and 2 (each within the scatter of the next); then compounds 4 and 3 (each within the scatter of the next).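

In this assay, morpholin-4-yl in place of 4-methylpiperazin-1-yl on the carbonyl carbon gives a 1.6-fold lower number from compound 3 to compound 4 (0.21 log units; within the scatter), so these two rings are not told apart at this position. The second hetero atom in the ring now appears with either oxygen or methyl-bearing nitrogen, and the morpholine stays clear of both smaller numbers, with a 3.5-fold higher number from compound 2 to compound 4 (0.55 log units; beyond the scatter) and a 7.1-fold higher number from compound 1 to compound 4 (0.85 log units; beyond the scatter). Nothing shown offers a reason for this. Going by these compounds, it remains open whether pyrrolidin-1-yl or an open-chain dimethylamino group on the same carbonyl carbon would fall with compound 2 or with compound 4.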